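The source may report more compounds than this note shows. Statements on the series, on what has been measured and on what is new or still open speak of the compounds shown alone.

Among the compounds with values here, compound 2 `O=C(/C=C/c1ccc(Cl)cc1)Nc1ccc2ncnc(Nc3cccc(Cl)c3)c2c1` gives 9.97 ug/mL in a functional assay on B16-F10 cells (Mus musculus) for inhibition, read by MTT assay, with a stated time of 48 h (on this read-out higher numbers stand for weaker inhibition and lower numbers for stronger inhibition), the higher of the two numbers measured so far. Compound 1 `COc1ccc(/C=C/C(=O)Nc2ccc3ncnc(Nc4cccc(Br)c4)c3c2)cc1` gives 1.24 ug/mL in this assay, and the gap between the two lies beyond the scatter. Compound 3 `O=C(/C=C/c1ccccc1Br)Nc1ccc2ncnc(Nc3cccc(Cl)c3)c2c1` differs from compound 2 in one place: 2-bromophenyl in place of 4-chlorophenyl on a double-bonded chain carbon bound to a double-bonded chain carbon. Within the data shown here, no measured pair shows what such a swap does on this core, so the number for compound 3 is expected to stay close to that of compound 2, with a step estimated as a 1.2-fold lower number from compound 2 to compound 3 (0.10 log units; within the scatter), not clearly beyond the scatter. Compound 3 is therefore expected at 8 ug/mL, within a range from 3 ug/mL to 25 ug/mL.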

Compound 3, half-maximal inhibitory concentration: 1.65 ug/mL
Beside the measured number, compound 3's estimate is 4.8-fold (0.69 log units) above it; measured number below the stated range.
By their numbers in this assay, from the lowest: compounds 1 and 3 (each within the scatter of the next); then compound 2.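

In this assay this position is clearly sensitive to the group it carries: 2-bromophenyl in place of 4-chlorophenyl on a double-bonded chain carbon bound to a double-bonded chain carbon gives a 6.0-fold lower number from compound 2 to compound 3 (0.78 log units; beyond the scatter) on the shared core. Within the data shown here, this swap changes both the halogen and its place on the ring, so the single step cannot be divided between the two. Nothing on hand explains the step. Still open, from the compounds shown here alone, is how 4-bromophenyl or 2-chlorophenyl would compare, which could separate those two changes. Also open, going by these compounds, is how a phenyl ring carrying an amine or a carboxylic acid would fare here.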